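The source may report more compounds than this note shows. Statements on the series, on what has been measured and on what is new or still open speak of the compounds shown alone.

Measured compounds:
compound 1, `CCCCCC(=O)c1ccc(CN(CCCCCCC(=O)O)S(C)(=O)=O)cc1`: > 3200 nM
compound 2, `CCCCc1ccc(CN(CCCCOCC(=O)O)S(C)(=O)=O)cc1`: > 3200 nM

In an assay on HEK293 cells for inhibition of prostaglandin E2 receptor EP4 subtype (Rattus norvegicus) (a lower number here means a stronger inhibitor, a higher number a weaker inhibitor), compound 1 gives > 3200 nM, which is a limit of the assay and not a number. Compound 2 in this assay likewise gives only a limit, > 3200 nM. Both measured values therefore sit at the limit of > 3200 nM in this assay, at which 2 of the 2 values shown sit, so compound 1 has no fixed place among the numbers, and the gap between compound 1 and compound 2 cannot be read from these two limits.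

Compound 3, `CS(=O)(=O)N(CCCCCCC(=O)O)Cc1ccc(-c2ccccc2)cc1`, differs from compound 1 by phenyl in place of pentylcarbonyl on an aromatic carbon. For the measured compounds named here, no step between measured compounds is known here, and the two limits give no direction for this change. The step that the limit leaves unreadable from compound 1 to compound 3 is expected to be small, with no direction beyond the scatter established. Compound 3 is estimated at 4000 nM in this assay, expected to fall between 1200 nM and 15000 nM.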

Compound 3, half-maximal inhibitory concentration: > 3200 nM
Compound 3: a limit, no number; the forecaster's own chance of this, stated with the estimate: 60%; the middle value lies beyond the limit too.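

In this assay compound 3 gives > 3200 nM, which is a limit of the assay and not a number, so no step can be read between compound 1 and compound 3: the limit of > 3200 nM in this assay, at which 3 of the 3 values shown sit.

The compounds shown leave open whether phenyl in place of pentylcarbonyl changes the result in this assay at all.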